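Removing the hydroxy from compound 3

This account rests on a few compounds, and the source may have more. Where it says the series, first, only, none or still open, it means among the compounds named here.

Values in a functional assay on KB cells (Homo sapiens) for antiproliferative activity, read by sulforhodamine B assay, with a stated time of 3 days; a higher number here means that more compound is needed for the effect, a lower number that less compound is needed:
- compound 1 `CCC1=C(O)c2c(oc(-c3ccc(OC)cc3)cc2=O)C(CC)(CC)C1=O` gives 17.7 uM
- compound 2 `CCC1=C(O)c2c(oc(-c3ccc(OC)c(Cl)c3)cc2=O)C(CC)(CC)C1=O` gives 24.9 uM
- compound 3 `CCC1=C(O)c2c(oc(-c3cc(C)c(O)c(C)c3)cc2=O)C(CC)(CC)C1=O` gives 18.3 uM

Compound 3 stands level with the other two within the scatter. The next structure is compound 4 `CCC1=C(O)c2c(oc(-c3cc(C)cc(C)c3)cc2=O)C(CC)(CC)C1=O`, with hydrogen in place of hydroxy on an aromatic carbon, ortho to two methyl groups.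

Among the compounds with values here, no measured step makes this exact change. The closest are the other changes on the same aromatic group: a 1.4-fold higher number from compound 1 to compound 2 (0.15 log units; within the scatter), a 1.0-fold higher number from compound 1 to compound 3 (0.01 log units; within the scatter) and a 1.4-fold lower number from compound 2 to compound 3 (0.13 log units; within the scatter). All three are small, so no shift beyond the scatter is expected in this assay. The expected step is a 1.1-fold higher number from compound 3 to compound 4 (0.04 log units; within the scatter). The estimate for compound 4 is 20 uM, within a range of 10 uM to 40 uM.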

Compound 4, concentration for half-maximal effect: 45.5 uM
Compound 4: the middle estimate sits 2.3-fold (0.36 log units) below what was measured; measured number outside the range, above it.
By their numbers in this assay, from the lowest: compounds 1, 3, 2 and 4 (each within the scatter of the next, the first and the last beyond it).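

Within the data shown here, replacing the hydroxy with hydrogen on this aromatic carbon, ortho to two methyl groups, gives the first change that clears the scatter in this assay (a 2.5-fold higher number from compound 3 to compound 4 (0.40 log units; beyond the scatter)). Compound 4 also separates from the methoxy compound (a 2.6-fold higher number from compound 1 to compound 4 (0.41 log units; beyond the scatter)). So hydroxy and methoxy read alike here while hydrogen reads higher, but compound 2 goes against this pattern, staying within the scatter of compound 4 (a 1.8-fold higher number from compound 2 to compound 4 (0.26 log units; within the scatter)).

Going by these compounds, whether an amine or a carboxylic acid on this carbon would read like hydroxy remains open. Nothing available explains the rise at this position.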